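The source may report more compounds than this note shows. Statements on the series, on what has been measured and on what is new or still open speak of the compounds shown alone.

The measured compounds in a functional assay on HCT-116 cells (Homo sapiens), read by MTT assay, with a stated time of 72 h (a lower number here means a stronger inhibitor, a higher number a weaker inhibitor), are these.

Compound 1 `COc1nc(N)nc2c1c(-c1ccccc1)cn2[C@@H]1O[C@H](CO)[C@@H](O)[C@H]1O` gives > 20000 nM, which is a limit of the assay rather than a number.
Compound 2 `Nc1nc(N)c2c(-c3ccccc3)cn([C@@H]3O[C@H](CO)[C@@H](O)[C@H]3O)c2n1` gives > 20000 nM, again a limit.
Compound 3 `Nc1nc(N)c2c(-c3cc4ccccc4o3)cn([C@@H]3O[C@H](CO)[C@@H](O)[C@H]3O)c2n1` gives > 20000 nM, also a limit.

Within the data shown here, all three values sit at the limit of > 20000 nM in this assay, at which 3 of the 3 values shown sit, so no compound among them can be placed above or below another. The change from compound 2 to compound 1 is methoxy in place of amino on an aromatic carbon, and the step it made, a step that the two limits leave unreadable from compound 2 to compound 1, cannot be read because both ends are limits. The cores of compound 2 and compound 3 differ by 1-benzofuran-2-yl in place of phenyl on an aromatic carbon, and the step that the two limits leave unreadable from compound 2 to compound 3 is likewise unreadable for the same reason.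

Compound 4 `COc1nc(N)nc2c1c(-c1cc3ccccc3o1)cn2[C@@H]1O[C@H](CO)[C@@H](O)[C@H]1O` has not yet been measured in this assay. It differs from compound 3 by methoxy in place of amino on an aromatic carbon, which is the same change as that from compound 2 to compound 1, with the place described in identical words; the change occurs in two pairs among these compounds. Since compound 3 itself shows only the limit > 20000 nM, and the earlier instance of this change left both partners at the limit, the expectation for compound 4 is that this assay will again return a limit rather than a number. The step is estimated as a step that the limit leaves unreadable from compound 3 to compound 4, resting on the two limits of compound 2 and compound 1. Compound 4 is accordingly estimated at 30000 nM, with a range from 20000 nM to 100000 nM.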

Compound 4, half-maximal inhibitory concentration: > 20000 nM
Compound 4 ended at the assay's limit; the forecaster's own chance of this, stated with the estimate: 90%; the middle value lies beyond the limit too.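

In this assay compound 4 gives > 20000 nM, which is a limit and not a number. Neither the step from compound 3 to compound 4 nor the one from compound 1 to compound 4 can be read, because both ends of each are limits: the limit of > 20000 nM in this assay, at which 4 of the 4 values shown sit.

The compounds shown leave open how compounds 1, 2, 3 and 4 rank against one another, and whether either change has any effect on the values in this assay.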